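A Chloro-for-Isopropyl Swap at a Weakly Active Starting Point

A few compounds are considered here, and "the series" means these few. Any claim that something is new, unique, unknown or untested is made for them only; others in the source may bear on it.

Measured compounds:
compound 1 `Cc1cnc(Nc2ccc(C(C)C)cc2)nc1Nc1nc2ccccc2s1`, > 50000 nM
compound 2 `Cc1ccc2nc(Nc3nc(Nc4ccc(S(C)(=O)=O)cc4)ncc3F)sc2c1`, 14300 nM

Of the compounds shown here, two have been measured in a functional assay on MDA-MB-231 cells (Homo sapiens) for antiproliferative activity, read by MTT assay, with a stated time of 48 h; a lower number here means a stronger inhibitor, a higher number a weaker inhibitor. In this assay compound 1 gives > 50000 nM, which is a limit of the assay rather than a number, so compound 1 stands at the limit of > 50000 nM in this assay, at which 1 of the 2 values shown sits. In this assay compound 2 gives 14300 nM. Going by the values given here, compound 1 and compound 2 differ in more than one place, so no single step connects them; their values show only that compound 2 returns a number where compound 1 does not.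

Compound 3 `Cc1cnc(Nc2ccc(Cl)cc2)nc1Nc1nc2ccccc2s1` has not yet been measured. It differs from compound 1 by chloro in place of isopropyl on an aromatic carbon. Among the compounds with values here, with compound 1 giving only a limit, there is no measured step to scale this change against, and the change counts few atoms. Compound 3 is therefore expected to remain weak in this assay. The step expected here is an at least 1.1-fold lower number from compound 1 to compound 3 (0.04 log units; that floor lies within the scatter), none beyond the usual scatter. The estimate for compound 3 in this assay is 45000 nM, within a range from 15000 nM to 150000 nM.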

Compound 3, half-maximal inhibitory concentration: > 50000 nM
Compound 3: no number, only a limit; the forecaster's own chance of this, stated with the estimate: 60%; middle value at least 1.1-fold (0.04 log units) from the limit.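

Compound 3, like compound 1, returns only a limit in this assay and not a number, so no step can be read between the two compounds: the limit of > 50000 nM in this assay, at which 2 of the 3 values shown sit. The compounds shown leave open how far chloro in place of isopropyl on an aromatic carbon shifts antiproliferative activity, if it does so at all.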